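A few compounds are considered here, and "the series" means these few. Any claim that something is new, unique, unknown or untested is made for them only; others in the source may bear on it.

Measured compounds in a functional assay on PC-3M cells (Homo sapiens) for cytotoxicity, read by MTT assay, with a stated time of 48 h; a lower number here means a stronger inhibitor, a higher number a weaker inhibitor:
- compound 1 `C=CCSc1nnc(CC)n1N1C(=O)c2ccccc2C1=O`: > 200000 nM (a limit of the assay, not a number)
- compound 2 `COc1cc(-c2nnc(SCc3ccccc3Cl)n2N2C(=O)c3ccccc3C2=O)cc(OC)c1OC`: > 200000 nM (a limit of the assay, not a number)
- compound 3 `COc1cc(-c2nnc(SC)n2N2C(=O)c3ccccc3C2=O)cc(OC)c1OC`: > 200000 nM (a limit of the assay, not a number)

Compound 3 stands nowhere that a number can fix: in this assay compound 3 gives only a limit, and both other measured values shown are limits as well, all sitting at the limit of > 200000 nM in this assay, at which 3 of the 3 values shown sit. Within the data shown here, the one change among measured compounds, from compound 2 to compound 3, reads a step that the two limits leave unreadable from compound 2 to compound 3, so it gives no size.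

Compound 4 `COc1ccc(C(=O)CSc2nnc(-c3cc(OC)c(OC)c(OC)c3)n2N2C(=O)c3ccccc3C2=O)cc1` differs from compound 3 by (4-methoxyphenyl)carbonyl in place of hydrogen on a saturated chain carbon bound to a sulfur. Among the measured compounds shown here, no measured step bears on this change with a readable size; the only step between measured compounds is the unreadable one from compound 2 to compound 3. Nothing in the series therefore points to a step in either direction beyond the scatter, and the shared core with its three measured variants has so far yielded limits only.

Compound 4 is expected to remain at or near the same limit, estimated at 180000 nM with a range from 25000 nM to 600000 nM. The step from compound 3 to compound 4 that this estimate means is an at least 1.1-fold lower number from compound 3 to compound 4 (0.04 log units; that floor lies within the scatter), an expectation of no readable change.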

Compound 4, half-maximal inhibitory concentration: 32800 nM
The estimate for compound 4 lay 5.5-fold (0.74 log units) above the measured number, within the range that was stated.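

Among these compounds, on the saturated chain carbon bound to a sulfur, (4-methoxyphenyl)carbonyl in place of hydrogen gives the first readable step in this assay: an at least 6.0-fold lower number from compound 3 to compound 4 (0.78 log units; beyond the scatter). Against 2-chlorophenyl at the same place, the same group reads an at least 6.0-fold lower number from compound 2 to compound 4 (0.78 log units; beyond the scatter), so a six-membered aromatic ring at this place is not enough by itself to give a number, as compound 2 carries one and remains a limit of the assay. Compound 4 alone gives a number, and the other compounds remain limits, not numbers: the limit of > 200000 nM in this assay, at which 3 of the 4 values shown sit.

The full size of both steps stays unknown, and the compounds shown do not separate the carbonyl from the 4-methoxyphenyl part of the entering group. Plain phenylcarbonyl, or a carboxylic acid or an amine at this place, would bear on that question.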